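Swapping the acid of compound 2 for a sulfur group

The source may hold more compounds than are shown below. What is called first, only, known or untested is meant among the compounds shown, and "the series" means these compounds.

Compound 2 `COc1ccc(COCC(Cn2ccnc2)OCc2ccc(C(=O)O)cc2)cc1` gives 6700 nM in a functional assay for inhibition of Thromboxane-A synthase (Homo sapiens) (on this read-out lower numbers stand for stronger inhibition and higher numbers for weaker inhibition), the higher of the two measured numbers. Compound 1 `COc1ccc(COCC(Cn2ccnc2)OCc2ccc(C(=O)Oc3ccccc3)cc2)cc1` gives 560 nM, and the step of a 12-fold higher number from compound 1 to compound 2 (1.08 log units; beyond the scatter) shows how strongly that change weakened inhibition. Compound 3 `COc1ccc(COCC(Cn2ccnc2)OCc2ccc([S+](C)[O-])cc2)cc1` differs from compound 2 by a group of 3 heavy atoms (1 carbon, 1 oxygen, 1 sulfur; no ring) in place of a group of 3 heavy atoms (1 carbon, 2 oxygen; no ring), on an aromatic carbon, removing the hydrogen-bond donor that the carboxy carried. Within the data shown here, no measured step covers this exact change, so only the large loss from compound 1 to compound 2 bears on it. For compound 3 a moderate gain is expected, a 4.5-fold lower number from compound 2 to compound 3 (0.65 log units; beyond the scatter), with an estimated 1500 nM between 300 nM and 8000 nM.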

Compound 3, half-maximal inhibitory concentration: 8600 nM
Estimate against measurement, compound 3: 5.7-fold (0.76 log units) below; the whole stated range lies below it.
By their numbers in this assay, from the lowest: compound 1; then compounds 2 and 3 (each within the scatter of the next).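

In this assay, exchanging the carboxy for the sulfur group leaves the number within the scatter (a 1.3-fold higher number from compound 2 to compound 3 (0.11 log units; within the scatter)), so losing the hydrogen-bond donor of the carboxy brings no measurable gain at this position. The larger group with its aromatic ring remains clearly ahead of the sulfur group (a 15-fold higher number from compound 1 to compound 3 (1.19 log units; beyond the scatter)), and among these three compounds only that larger group stands apart. Nothing available explains why the two small groups read alike. On these data alone, whether an amine or a benzyl ether on this aromatic carbon would read like the small groups or like the larger one remains open.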